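The source may hold more compounds than are shown below. What is called first, only, known or untested is meant among the compounds shown, and "the series" means these compounds.

Compound 1 `CCCNS(=O)(=O)c1ccc(Nc2ncc3c(n2)N(C2CCCC2)[C@H](CC)C(=O)N3C)cc1` is the most potent of the three compounds measured in a functional assay on MCF7 cells (Homo sapiens) for antiproliferative activity, read by CCK-8 assay, with a stated time of 72 h; on this read-out lower numbers stand for stronger inhibition of growth and higher numbers for weaker inhibition of growth: compound 1 gives 344 nM. Compound 3 `CC[C@@H]1C(=O)N(C)c2cnc(-n3ccc4cc(C(=O)NC5CCCC5)ccc43)nc2N1C1CCCC1` comes nearest, with 795 nM in this assay, a gap beyond the usual scatter, and compound 2 `CCC1C(=O)N(C)c2cnc(-n3ccc4cc(C(=O)NC)ccc43)nc2N1c1ccn(C)n1` lies furthest, at 35400 nM in this assay. Compound 4 `CC[C@@H]1C(=O)N(C)c2cnc(Nc3ccc(S(=O)(=O)NCCCO)cc3)nc2N1C1CCCC1` has not yet been tested in this assay. It differs from compound 1 by hydroxy in place of hydrogen on a saturated chain carbon, three bonds along the chain from a sulfonamide nitrogen, the rest of compound 1 being unchanged. With only a hydroxy added at the end of a short chain, the expected step, a 1.1-fold higher number from compound 1 to compound 4 (0.04 log units; within the scatter), is none beyond the scatter, in either direction. Compound 4 is therefore estimated at 380 nM in this assay, within a range of 160 nM to 900 nM.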

Compound 4, concentration for 50% growth inhibition: 363 nM
The estimate for compound 4 lay 1.0-fold (0.02 log units) above the measured number; low and high end bracket the measured number.
By their numbers in this assay, from the lowest: compounds 1 and 4 (each within the scatter of the next); then compound 3; then compound 2.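

In this assay, the change from propyl to 3-hydroxypropyl gives a 1.1-fold higher number from compound 1 to compound 4 (0.02 log units; within the scatter), so hydroxy is accepted on this saturated chain carbon, three bonds along the chain from a sulfonamide nitrogen, without a change beyond the scatter. Within the data shown here, the earlier compounds offered no pair differing in one place, so this is the first reading of any single change. No measurement at hand explains why the number holds. As far as these compounds go, whether an amine, a carboxylic acid or a longer chain would be accepted at this chain end remains open.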